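The source may report more compounds than this note shows. Statements on the series, on what has been measured and on what is new or still open speak of the compounds shown alone.

Compound 1 `COc1ccc2nc(C)cc(OCC(=O)Nc3ccc(Br)cc3)c2c1` was run in an ADME assay on HepG2 cells (Homo sapiens) for cytotoxicity, read by trypan blue exclusion, with a stated time of 48 h, in the presence of a further agent that is not named here; on this read-out higher numbers stand for lower toxicity in this test and lower numbers for higher toxicity in this test. In this assay compound 1 gave only a limit, > 125000 nM. Compound 2 `COc1ccc2nc(C)cc(OCC(=O)Nc3ccccc3Cl)c2c1` differs from it by a 2-chlorophenyl in place of a 4-bromophenyl on an amide-type nitrogen. In this assay compound 2 likewise gave only a limit, > 140000 nM. The step that the two limits leave unreadable from compound 1 to compound 2 is accordingly not readable. Compound 2 thus stands at a limit (the limit of > 140000 nM in this assay, at which 1 of the 2 values shown sits). Among the measured compounds shown here, the one further value shown is also a limit (the limit of > 125000 nM in this assay, at which 1 of the 2 values shown sits).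

Compound 3 `C#CCNC(=O)COc1cc(C)nc2ccc(OC)cc12` has not been measured; it differs from compound 2 by propargyl in place of 2-chlorophenyl on an amide-type nitrogen. The only measured step that bears on this change is a step that the two limits leave unreadable from compound 1 to compound 2, and because the limit of > 125000 nM in this assay, at which 1 of the 2 values shown sits, and the limit of > 140000 nM in this assay, at which 1 of the 2 values shown sits, both sit at limits, its size cannot be read, so neither a direction nor a size beyond the scatter can be drawn from it; the exchange of an aromatic group for a short chain has no measured counterpart among these compounds. The step that the limit leaves unreadable from compound 2 to compound 3 is therefore expected to be small, with compound 3 most likely again reported only as a limit. Compound 3 is estimated at 150000 nM, within 50000 nM to 500000 nM.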

Compound 3, half-maximal cytotoxic concentration: > 176000 nM
Compound 3: no number, only a limit (the forecaster's own chance of this, stated with the estimate: 80%); at least 1.1-fold (0.06 log units) between middle value and limit.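

Compound 1, compound 2 and compound 3 all stand only at limits in this assay, so no step among these three compounds can be read. The compounds shown leave open how far apart their half-maximal cytotoxic concentrations lie, and whether any of the three groups on the amide-type nitrogen gives a number in this test at all.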